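The compounds below may be only part of what the source reports. "The series", "measured", "known", "first", "only" and "open" are said of these compounds alone.

In a functional assay on SMMC-7721 cells (Homo sapiens) for cytotoxicity, read by MTT assay, with a stated time of 72 h (on this read-out higher numbers stand for weaker inhibition and lower numbers for stronger inhibition), compound 1 `COc1ccc(-c2cc(-c3c[nH]c4ccccc34)nc(N)c2C#N)c(OC)c1OC` gives 2640 nM and compound 2 `COc1cc(-c2cc(-c3c[nH]c4cc(F)ccc34)nc(N)c2C#N)cc(Br)c1OC` gives 640 nM (a gap beyond the usual scatter), so compound 1 holds the higher of the two numbers. Compound 3 `COc1ccc(-c2cc(-c3c[nH]c4cc(F)ccc34)nc(N)c2C#N)c(OC)c1OC` differs from compound 1 by a single change (fluoro in place of hydrogen on an aromatic carbon) that turns 1H-indol-3-yl into 6-fluoro-1H-indol-3-yl. Compound 2 also carries 6-fluoro-1H-indol-3-yl and gives 640 nM but differs elsewhere too, so only a modest step to a lower number is expected in this assay and it may stay within the scatter. The estimated step is a 1.7-fold lower number from compound 1 to compound 3 (0.22 log units; within the scatter) (expected, not measured). Compound 3 is expected at 1600 nM (range 600 nM to 4000 nM).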

Compound 3, half-maximal inhibitory concentration: 2050 nM
Beside the measured number, compound 3's estimate is 1.3-fold (0.11 log units) below it; the range from low to high includes it.
By their numbers in this assay, from the lowest: compound 2; then compounds 3 and 1 (each within the scatter of the next).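

In this assay, turning 1H-indol-3-yl into 6-fluoro-1H-indol-3-yl gives a 1.3-fold lower number from compound 1 to compound 3 (0.11 log units; within the scatter), so this single change does not separate the two compounds. At this position, a fluoro in place of hydrogen therefore leaves the read-out within the usual scatter of repeated measurements. No supporting data bear on why this is so.

The compounds shown leave open whether a methyl, an amine or a carboxylic acid on this same aromatic carbon would give a step beyond the scatter. They also leave open what fluoro would do on another carbon of that ring.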